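The source may report more compounds than this note shows. Statements on the series, on what has been measured and on what is new or still open speak of the compounds shown alone.

In a functional assay on HepG2 cells (Homo sapiens), read by MTT assay, with a stated time of 48 h (on this read-out higher numbers stand for weaker inhibition and lower numbers for stronger inhibition), compound 1 `CCOC(=O)CN(C)C(=O)c1ccc(C(CC)(CC)c2ccc(OCC(O)C(C)(C)C)c(C)c2)n1CC` reads > 50000 nM, which is a limit of the assay and not a number. Compound 2 `CCn1c(C(=O)NCC(OC)OC)ccc1C(CC)(CC)c1ccc(OCC(O)C(C)(C)C)c(C)c1` gives 23200 nM. Compound 3 `CCn1c(C(=O)NCCN)ccc1C(CC)(CC)c1ccc(OCC(O)C(C)(C)C)c(C)c1` gives 176 nM, the lowest number of the set. Compound 4 `C=CCN(C)C(=O)c1ccc(C(CC)(CC)c2ccc(OCC(O)C(C)(C)C)c(C)c2)n1CC` carries allyl(methyl)amino in place of (2-aminoethyl)amino on a carbonyl carbon. For the measured compounds named here, two large steps bear on this change, an at least 280-fold lower number from compound 1 to compound 3 (2.45 log units; beyond the scatter) and a 130-fold lower number from compound 2 to compound 3 (2.12 log units; beyond the scatter), and both end at the only compound with (2-aminoethyl)amino. The modest at least 2.1-fold lower number from compound 1 to compound 2 (0.33 log units; beyond the scatter) stays far from that low number. Compound 4 also lacks (2-aminoethyl)amino, so those large steps are expected to run in reverse. The expected change is a 140-fold higher number from compound 3 to compound 4 (2.15 log units; beyond the scatter), a large rise in the number. For compound 4 the estimated value is 25000 nM, with an expected range of 8000 nM to 50000 nM.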

Compound 4, half-maximal inhibitory concentration: > 50000 nM
Compound 4 ended at the assay's limit; the forecaster's own chance of this, stated with the estimate: 35%; middle value at least 2.0-fold (0.30 log units) away from the limit.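

Swapping (2-aminoethyl)amino for allyl(methyl)amino on this carbonyl carbon gives an at least 280-fold higher number from compound 3 to compound 4 (2.45 log units; beyond the scatter), so a third group without the amine also fails to keep the low number. The same position separates the two amides without that amine, with an at least 2.1-fold higher number from compound 2 to compound 4 (0.33 log units; beyond the scatter). Compound 4 sits at a limit, as compound 1 does, so the step between them cannot be read: the limit of > 50000 nM in this assay, at which 2 of the 4 values shown sit.

On these data alone, whether the amine alone matters, or also the amide hydrogen that compound 3 keeps and compound 4 lacks, stays open. (2-Aminoethyl)(methyl)amino would pair that amine with a methyl on the amide nitrogen, and (3-aminopropyl)amino would test a longer chain.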